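The source may report more compounds than this note shows. Statements on the series, on what has been measured and on what is new or still open speak of the compounds shown alone.

Of the compounds shown here, three of this set have been tested in an ADME assay on HEK293 cells (Homo sapiens) for cytotoxicity, read by luminescence, with a stated time of 72 h (on this read-out lower numbers stand for an effect already at smaller amounts and higher numbers for an effect only at larger amounts of compound), and a fourth awaits its turn. Compound 1 `CCOC(=O)c1c(-c2cccc(OC(C)C)c2)[nH]c2cc(OC)ccc2c1=O` carries an isopropyl group on an oxygen of an aromatic ring, and compound 2 `CCOC(=O)c1c(-c2cccc(O)c2)[nH]c2cc(OC)ccc2c1=O` is the same molecule with that group taken away: hydrogen in place of isopropyl on an oxygen on an aromatic ring. In this assay compound 1 gives only a limit, > 22000 nM. Compound 2 likewise gives only a limit, > 22000 nM. The step between them is therefore a step that the two limits leave unreadable from compound 1 to compound 2. Compound 3 `CCOC(=O)c1c(-c2cccc(-c3ccccc3)c2)[nH]c2cc(OC(C)C)ccc2c1=O` has a different core; how its core differs from that of compound 1 is not broken down here. In this assay compound 3 also reaches only a limit, > 22000 nM. All three values thus sit at the limit of > 22000 nM in this assay, at which 3 of the 3 values shown sit. Compound 4 `CCOC(=O)c1c(-c2cccc(-c3ccccc3)c2)[nH]c2cc(O)ccc2c1=O` is made from compound 3 by the same change, which occurs twice among these compounds: hydrogen in place of isopropyl on an oxygen on an aromatic ring. Because compound 1 and compound 2 both rest at the limit (the limit of > 22000 nM in this assay, at which 3 of the 3 values shown sit), the step from compound 3 to compound 4 is expected to be small, a step that the limit leaves unreadable from compound 3 to compound 4. Compound 4 is accordingly expected to give about 30000 nM, somewhere from 15000 nM to 60000 nM, most likely again as a limit.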

Compound 4, half-maximal effective concentration: > 22000 nM
Compound 4 gave a limit, no number; the forecaster's own chance of this, stated with the estimate: 85%; the middle value is on the limit's open side.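

Among these compounds, compound 3 and compound 4 both give only a limit, so the step between them cannot be read, any more than the one between compound 1 and compound 2: (the limit of > 22000 nM in this assay, at which 4 of the 4 values shown sit). The compounds shown leave open at what concentration, if any, these four would show an effect in this assay and whether isopropoxy to hydroxy changes it.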